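Chloro-to-methyl swap on the benzyl ring of the thiazolidinedione series

The compounds below may be only part of what the source reports. "The series", "measured", "known", "first", "only" and "open" are said of these compounds alone.

Measured compounds:
compound 1 `C=C(Br)C(=O)Nc1cccc(/C=C2\SC(=O)N(Cc3ccc(C)cc3)C2=O)c1`, 600 nM
compound 2 `C=C(Br)C(=O)Nc1cccc(/C=C2\SC(=O)N(Cc3ccc(Cl)cc3)C2=O)c1`, 940 nM
compound 3 `Nc1ccc(/C=C2\SC(=O)N(Cc3ccc(Cl)cc3)C2=O)cc1`, 37000 nM

In a functional assay on L1210 cells (Mus musculus) for cytotoxicity, read by cell counting, with a stated time of 2 days (a lower number here means a stronger inhibitor, a higher number a weaker inhibitor), compound 1 gives 600 nM and compound 2 gives 940 nM. The two differ by methyl in place of chloro on an aromatic carbon, and the step is a 1.6-fold lower number from compound 2 to compound 1 (0.19 log units; within the scatter). Compound 3 gives 37000 nM in this assay, the highest of the three numbers. The difference between the core of compound 3 and the core of compound 2 is not broken down here.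

Compound 4 `Cc1ccc(CN2C(=O)S/C(=C\c3ccc(N)cc3)C2=O)cc1` is not yet measured. It differs from compound 3 by methyl in place of chloro on an aromatic carbon, the same change as between compound 2 and compound 1. The expected step is a 1.5-fold lower number from compound 3 to compound 4 (0.17 log units; within the scatter), because a 1.6-fold lower number from compound 2 to compound 1 (0.19 log units; within the scatter) lies within the scatter and compound 3 sits at 37000 nM. For compound 4 the estimate in this assay is 25000 nM, with a range from 10000 nM to 60000 nM.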

Compound 4, half-maximal inhibitory concentration: 94000 nM
Beside the measured number, compound 4's estimate is 3.8-fold (0.58 log units) below it; measured number outside the range, above it.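

In this assay, replacing 4-chlorophenyl with 4-methylphenyl on the core of compound 3 gives a 2.5-fold higher number from compound 3 to compound 4 (0.40 log units; beyond the scatter). Set beside the same change on the core of compound 2, the step does not carry over unchanged: the same change on two cores in this assay, a 1.6-fold lower number (0.19 log units; within the scatter) from compound 2 to compound 1 and a 2.5-fold higher number (0.40 log units; beyond the scatter) from compound 3 to compound 4, 4.0-fold (0.60 log units) apart, beyond the scatter of two such steps. This shows that, across these two pairs, the outcome of the swap depends on the core, but with one pair per core it does not show which feature of the cores matters or give a rule for the wider series.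

Open, as far as these compounds go, is how other groups in the same place, such as fluoro, methoxy or a carboxylic acid, would behave on each core. Also open, from the compounds shown here alone, is whether the same core dependence would appear with those groups.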